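Swapping the Ring on the Core Nitrogen: Compound 3 Expected

The source may hold more compounds than are shown below. What is called first, only, known or untested is meant among the compounds shown, and "the series" means these compounds.

Measured so far:
compound 1 `CCOc1ccc(-n2cnc3cnc(-c4ccc(F)cc4C)cc32)cc1`: 19 nM
compound 2 `Cc1ccc(-n2cnc3cnc(-c4ccc(F)cc4C)cc32)cc1`: 140 nM

In a functional assay on HL-60 cells (Homo sapiens) for activation, read by flow cytometry, with a stated time of 4 days (on this read-out higher numbers stand for an effect only at larger amounts of compound and lower numbers for an effect already at smaller amounts), compound 2 gives the highest number of the two, with compound 1 the nearest, and the step of a 7.4-fold higher number from compound 1 to compound 2 (0.87 log units; beyond the scatter) lies beyond the scatter. Compound 3 `COc1cnc(-n2cnc3cnc(-c4ccc(F)cc4C)cc32)cn1` differs from compound 2 by 5-methoxypyrazin-2-yl in place of 4-methylphenyl on an aromatic nitrogen. For the measured compounds named here, the only measured change at this place is that same step, where an ethoxy gave the lower number. A methoxy within the entering group is closer to ethoxy than to methyl, but nothing measured speaks to exchanging the carbon ring for one with two nitrogens. In this assay a drop of the number is expected for compound 3, with wide uncertainty, a 3.5-fold lower number from compound 2 to compound 3 (0.54 log units; beyond the scatter). Compound 3 is estimated at 40 nM, expected within 10 nM to 160 nM.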

Compound 3, half-maximal effective concentration: 3700 nM
Compound 3: the middle estimate sits 93-fold (1.97 log units) below what was measured; the measured number lies above the stated range.
By their numbers in this assay, from the lowest: compound 1; then compound 2; then compound 3.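

In this assay, 5-methoxypyrazin-2-yl in place of 4-methylphenyl on the aromatic nitrogen gives a 26-fold higher number from compound 2 to compound 3 (1.42 log units; beyond the scatter). The earlier step changed only the group carried by a carbon ring; this one shows that replacing the ring itself can shift the number sharply upward. Nothing available explains this shift.

Going by these compounds, the ring nitrogens and the methoxy enter together, so their separate contributions remain open. On these data alone, how 4-methoxyphenyl, or a pyrazine ring bearing an amine instead of methoxy, would behave at this position also remains open.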